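Pyridin-3-yl in place of phenyl on the propenyl chain

The source may report more compounds than this note shows. Statements on the series, on what has been measured and on what is new or still open speak of the compounds shown alone.

Compound 3 `O[C@@H](c1ccccc1)[C@H]1CO[C@H](c2ccccc2)[C@@H](C/C=C/c2ccccc2)C1` stands lowest of the two numbers in a functional assay on HeLa cells (Homo sapiens) for cytotoxicity, read by WST assay, with a stated time of 48 h (a higher number here means a weaker inhibitor, a lower number a stronger inhibitor), at 6060 nM. Compound 2 `Oc1cccc(/C=C/C[C@H]2C[C@@H]([C@@H](O)c3ccccc3)CO[C@@H]2c2ccccc2)c1` gives 18600 nM in this assay. Compound 1 `O[C@@H](c1ccccc1)[C@H]1CO[C@H](c2ccccc2)[C@@H](C/C=C/c2ccncc2)C1` reports only a limit in this assay, > 100000 nM, as recorded by the limit of > 100000 nM in this assay, at which 1 of the 3 values shown sits. The step of a 3.1-fold lower number from compound 2 to compound 3 (0.49 log units; beyond the scatter) is modest; the step of an at least 16-fold lower number from compound 1 to compound 3 (1.21 log units; beyond the scatter) is large, and an at least 5.3-fold lower number from compound 1 to compound 2 (0.73 log units; beyond the scatter) is at least modest. Compound 4 `O[C@@H](c1ccccc1)[C@H]1CO[C@H](c2ccccc2)[C@@H](C/C=C/c2cccnc2)C1` differs from compound 3 by pyridin-3-yl in place of phenyl on a double-bonded chain carbon bound to a double-bonded chain carbon. The most pertinent precedent is the large step because an at least 16-fold lower number from compound 1 to compound 3 (1.21 log units; beyond the scatter) shows that pyridin-4-yl at the same place gives a far higher number than phenyl; pyridin-3-yl is a different isomer, so a smaller rise is expected. Compound 4 is expected to give 30000 nM, ranging from 8000 nM to 100000 nM. For compound 4 this amounts to an expected step of a 5.0-fold higher number from compound 3 to compound 4 (0.69 log units; beyond the scatter).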

Compound 4, half-maximal inhibitory concentration: > 100000 nM
Compound 4: a limit, no number (the forecaster's own chance of this, stated with the estimate: 30%); middle value at least 3.3-fold (0.52 log units) away from the limit.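

Pyridin-3-yl in place of phenyl gives an at least 16-fold higher number from compound 3 to compound 4 (1.21 log units; beyond the scatter) in this assay, so the rise seen with pyridin-4-yl at this place is not confined to that isomer. Pyridin-3-yl in place of 3-hydroxyphenyl gives an at least 5.3-fold higher number from compound 2 to compound 4 (0.73 log units; beyond the scatter), so the phenyl and 3-hydroxyphenyl compounds give readable numbers, while both pyridine compounds do not. The step between the two pyridine isomers cannot be read, as both compounds are limits: the limit of > 100000 nM in this assay, at which 2 of the 4 values shown sit.

Going by these compounds, whether a pyridin-2-yl or 3-aminophenyl group on the chain would give a readable number remains open.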